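The compounds below may be only part of what the source reports. "The series", "measured", "known", "first", "only" and "open" are said of these compounds alone.

Compound 1 `Cc1ccc(S/C(=C/c2sccc2C)C(=O)c2ccc(Br)cc2)cc1`: 50000 nM
Compound 2 `Cc1ccc(S/C(=C/c2ccc(F)c(C)c2)C(=O)c2ccc(Br)cc2)cc1`: 25000 nM
Compound 3 `Cc1ccc(S/C(=C/c2ccc(Cl)c(Cl)c2)C(=O)c2ccc(Br)cc2)cc1`: 50000 nM

In a functional assay on DU-145 cells (Homo sapiens) for inhibition, read by trypan blue exclusion, with a stated time of 96 h (a lower number here means a stronger inhibitor of growth, a higher number a weaker inhibitor of growth), compound 3 gives 50000 nM, level with compound 1 at the digits shown, and all three values lie within the scatter of one another. Compound 4 `COc1ccccc1/C=C(/Sc1ccc(C)cc1)C(=O)c1ccc(Br)cc1` carries 2-methoxyphenyl in place of 3,4-dichlorophenyl on a double-bonded chain carbon bound to a double-bonded chain carbon. Three measured swaps at this place bear on it: a 2.0-fold lower number from compound 1 to compound 2 (0.30 log units; within the scatter), no change at the digits printed from compound 1 to compound 3 (within the scatter) and a 2.0-fold higher number from compound 2 to compound 3 (0.30 log units; within the scatter). Going by the values given here, none goes beyond the scatter, though no measured compound carries 2-methoxyphenyl. In this assay no step beyond the scatter is therefore expected. The estimated step is a 1.3-fold lower number from compound 3 to compound 4 (0.10 log units; within the scatter). Compound 4 is estimated at 40000 nM, with an expected range of 18000 nM to 80000 nM.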

Compound 4, concentration for 50% growth inhibition: 9000 nM
Estimate against measurement, compound 4: 4.4-fold (0.65 log units) above, and the stated range ends above it.
By their numbers in this assay, from the lowest: compound 4; then compounds 2, 1 and 3 (each within the scatter of the next).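

In this assay, going by these compounds alone, this place on a double-bonded chain carbon bound to a double-bonded chain carbon moves the number beyond the scatter for the first time: 2-methoxyphenyl gives (a 5.6-fold lower number from compound 3 to compound 4 (0.74 log units; beyond the scatter)) and (a 5.6-fold lower number from compound 1 to compound 4 (0.74 log units; beyond the scatter)) as well as (a 2.8-fold lower number from compound 2 to compound 4 (0.44 log units; beyond the scatter)), making compound 4 the strongest inhibitor of growth of the four. The entering group carries one hydrogen-bond acceptor, whereas 3,4-dichlorophenyl carries none. Nothing measured here accounts for the gain. Going by these compounds, whether the methoxy group itself matters, or only 2-methoxyphenyl as a whole, stays open. So does the effect of a hydroxyl group or an amine at this place.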